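Methoxy on the shared core of compound 1

A few compounds are considered here, and "the series" means these few. Any claim that something is new, unique, unknown or untested is made for them only; others in the source may bear on it.

Within the data shown here, in an ADME assay on MT4 cells (Homo sapiens) for cytotoxicity, read by MTT assay, with a stated time of 4 days (on this read-out higher numbers stand for lower toxicity in this test and lower numbers for higher toxicity in this test), compound 1 (`CC(=O)Nc1ccc2oc(-c3ccccc3)cc(=O)c2c1`) gives 184000 nM and stands highest of the two numbers so far, with compound 2 (`CC(=O)Nc1ccc2oc(-c3cccc(C(F)(F)F)c3)cc(=O)c2c1`) at 10000 nM in the same read-out. Compound 3 (`COc1c(-c2ccccc2)oc2ccc(NC(C)=O)cc2c1=O`) has methoxy in place of hydrogen on an aromatic carbon. Among the measured compounds shown here, the only measured step is an 18-fold lower number from compound 1 to compound 2 (1.26 log units; beyond the scatter) and it is large, yet that change brings trifluoromethyl and not methoxy, so it bears only loosely here. In this assay the expected step is a 2.3-fold lower number from compound 1 to compound 3 (0.36 log units; beyond the scatter) and it is expected to be smaller than that one. Compound 3 is estimated at 80000 nM within an expected range (25000 nM to 220000 nM).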

Compound 3, half-maximal cytotoxic concentration: 200000 nM
For compound 3 the middle estimate is 2.5-fold (0.40 log units) below the measured one, and the stated range covers the measured number.
By their numbers in this assay, from the lowest: compound 2; then compounds 1 and 3 (each within the scatter of the next).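

In this assay, methoxy in place of hydrogen on this aromatic carbon, two atoms from the ring oxygen, gives a 1.1-fold higher number from compound 1 to compound 3 (0.04 log units; within the scatter). Among these compounds, this position of the shared core therefore takes methoxy with no step beyond the scatter, something compound 2, the only earlier change, could not show. As far as these compounds go, whether a hydroxyl, an amine or a longer chain on this same carbon would also stay within the scatter of compound 1 remains open. No measurement shown here accounts for this result.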